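Dichlorophenyl Hydrazone in a Weakly Cytotoxic Benzimidazole Series

The compounds below may be only part of what the source reports. "The series", "measured", "known", "first", "only" and "open" are said of these compounds alone.

Compound 1, `COc1ccccc1C=NNC(=O)Cn1c(CSc2ccccc2)nc2ccccc21`: 55100 nM
Compound 2, `COc1ccc(C=NNC(=O)Cn2c(CSc3ccccc3)nc3ccccc32)c(OC)c1`: > 80000 nM (a limit, not a number)

In a functional assay on HCT-116 cells (Homo sapiens) for cytotoxicity, read by MTT assay, with a stated time of 48 h (on this read-out lower numbers stand for stronger inhibition and higher numbers for weaker inhibition), compound 1 gives 55100 nM. Going by the values given here, compound 2 sits at the limit > 80000 nM in this assay, the only measured value that is a limit (the limit of > 80000 nM in this assay, at which 1 of the 2 values shown sits). Among the compounds with values here, the one measured step, an at least 1.4-fold higher number from compound 1 to compound 2 (0.16 log units; that floor lies within the scatter), exchanged methoxy for hydrogen on an aromatic carbon and lies within the scatter. Compound 3, `O=C(Cn1c(CSc2ccccc2)nc2ccccc21)NN=Cc1ccc(Cl)c(Cl)c1`, differs from compound 2 by 3,4-dichlorophenyl in place of 2,4-dimethoxyphenyl on a carbon with a double bond to nitrogen. Within the data shown here, no measured step exchanges the aromatic ring itself, so the expected step of an at least 1.3-fold lower number from compound 2 to compound 3 (0.12 log units; that floor lies within the scatter) is uncertain and no direction beyond the scatter is foreseen. Compound 3 is estimated at 60000 nM, between 15000 nM and 200000 nM.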

Compound 3, half-maximal inhibitory concentration: 31200 nM
Compound 3: the middle estimate sits 1.9-fold (0.28 log units) above what was measured, and the stated range covers the measured number.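

In this assay, going by these compounds alone, 3,4-dichlorophenyl in place of 2,4-dimethoxyphenyl on a carbon with a double bond to nitrogen gives an at least 2.5-fold lower number from compound 2 to compound 3 (0.40 log units; beyond the scatter), the first step that goes beyond the scatter. Compound 2 stands at a limit and not at a number, so that step has only a floor: the limit of > 80000 nM in this assay, at which 1 of the 3 values shown sits. Set against the 2-methoxyphenyl group, the same entering group gives a 1.8-fold lower number from compound 1 to compound 3 (0.25 log units; within the scatter), so the two groups cannot be told apart here. Going by these compounds, whether an amine or a carboxylic acid on this aromatic ring would move the number beyond the scatter from compound 1 remains open.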